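Halogen swap on a simpler core

This account rests on a few compounds, and the source may have more. Where it says the series, first, only, none or still open, it means among the compounds named here.

Three compounds have been measured in an assay on isolated protein for inhibition of Calpain-1 catalytic subunit (Sus scrofa), read by FRET; a higher number here means a weaker inhibitor, a lower number a stronger inhibitor:
compound 1 `O=C(O)/C(S)=C/c1c[nH]c2cc(Br)ccc12` gives 7 nM
compound 2 `O=C(O)/C(S)=C/c1c[nH]c2cc(Cl)ccc12` gives 210 nM
compound 3 `O=C(O)/C(S)=C/c1ccccc1Cl` gives 11900 nM

Compounds 1 and 2 share one core; compound 3 has another, and the difference between the two cores is not broken down here. In this assay compound 3 stands highest of the three. Between compound 2 and compound 1 the change is bromo in place of chloro on an aromatic carbon, and the step is a 30-fold lower number from compound 2 to compound 1 (1.48 log units; beyond the scatter). Compound 4 `O=C(O)/C(S)=C/c1ccccc1Br` has not yet been measured. It differs from compound 3 by bromo in place of chloro on an aromatic carbon, the same kind of change, though not the same: in compound 1 the place is part of a fused or bridged system of two rings, meta to a fused ring and para to a fused ring, whereas in compound 4 it is on a six-membered aromatic ring of carbon only, ortho to a group of 6 heavy atoms. Because a 30-fold lower number from compound 2 to compound 1 (1.48 log units; beyond the scatter) was made on a different core, a smaller step is expected here, estimated at a 4.0-fold lower number from compound 3 to compound 4 (0.60 log units; beyond the scatter). Compound 4 is therefore expected to give about 3000 nM in this assay, between 800 nM and 12000 nM.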

Compound 4, half-maximal inhibitory concentration: 21000 nM
Beside the measured number, compound 4's estimate is 7.0-fold (0.85 log units) below it; measured number above the stated range.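

In this assay, within the data shown here, bromo in place of chloro on an aromatic carbon gives a 1.8-fold higher number from compound 3 to compound 4 (0.25 log units; within the scatter) and so leaves no step on this core that can be told from the scatter. Set beside the earlier step, the change does not carry over from one core to the other: the same change on two cores in this assay, a 30-fold lower number (1.48 log units; beyond the scatter) from compound 2 to compound 1 and a 1.8-fold higher number (0.25 log units; within the scatter) from compound 3 to compound 4, 53-fold (1.72 log units) apart, beyond the scatter of two such steps. Among these compounds, this shows that the large step seen on the core of compound 1 cannot be taken as a property of the halogen swap alone, but with only one pair on each core it does not show whether the gap follows from the cores themselves or from the different places of the halogen.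

The compounds shown leave open what an iodo or a methyl group in the same place would give on either core. They also leave open whether the gap between the two steps would persist with an ester in place of the carboxylic acid.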